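Dimethylamino in place of methyl on a thiourea analogue

The source may report more compounds than this note shows. Statements on the series, on what has been measured and on what is new or still open speak of the compounds shown alone.

Compound 1: `COc1cc(/C=C/C(=O)C2=C(/C=C/c3ccc(O)c(OC)c3)NC(=O)NC2c2ccc(N(C)C)cc2)ccc1O`, 48%
Compound 2: `COc1cc(/C=C/C(=O)C2=C(/C=C/c3ccc(O)c(OC)c3)NC(=O)NC2c2cccc([N+](=O)[O-])c2)ccc1O`, 66.3%
Compound 3: `COc1cc(/C=C/C(=O)C2=C(/C=C/c3ccc(O)c(OC)c3)NC(=S)NC2c2ccc(C)cc2)ccc1O`, 51%

In a functional assay, with a stated time of 20 min, tested at 20 uM (on this read-out higher numbers stand for a stronger effect at the one concentration tested and lower numbers for a weaker effect), compound 3 stands second highest of the three numbers, within the scatter of compound 1 and beyond it only against compound 2. The unmeasured compound 4 is `COc1cc(/C=C/C(=O)C2=C(/C=C/c3ccc(O)c(OC)c3)NC(=S)NC2c2ccc(N(C)C)cc2)ccc1O`; the change is dimethylamino in place of methyl on an aromatic carbon, on an aromatic carbon para to a large group. Going by the values given here, the one measured step, a number 18.3 percentage points higher from compound 1 to compound 2 (beyond the scatter), concerns a different swap on the saturated ring carbon and so bears little on this change. Compound 1 already carries the dimethylamino group and gives 48%, close to compound 3. A step of a number 3 percentage points lower from compound 3 to compound 4 (within the scatter) is therefore expected, not beyond the scatter. Compound 4 is estimated at 48%, ranging from 35% to 62%.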

Compound 4, a percentage reported as activity, at one concentration (the size of the read-out at that concentration, not a potency): 83%
The estimate for compound 4 lay 35 percentage points below the measured number, outside the stated range (above it).
By their numbers in this assay, from the lowest: compounds 1 and 3 (each within the scatter of the next); then compound 2; then compound 4.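

In this assay the swap of 4-methylphenyl to 4-(dimethylamino)phenyl on the thiourea analogue gives a number 32 percentage points higher from compound 3 to compound 4 (beyond the scatter), so the number is sensitive to the group at this place. The group alone does not set the number: compound 1 gives 48% with the same group and a carbonyl, and compound 4 gives 83% with a thiocarbonyl in its stead. Nothing measured here explains the rise. As far as these compounds go, whether an unsubstituted amino group or a methoxy group on the same aromatic carbon would match compound 4 stays open.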